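A Group Swap With Little Change Expected

The compounds below may be only part of what the source reports. "The series", "measured", "known", "first", "only" and "open" are said of these compounds alone.

In a functional assay (aorta) with Rattus norvegicus as the target (on this read-out lower numbers stand for stronger inhibition and higher numbers for weaker inhibition), compound 3 (`CSc1cccc(N/C(=N/[C@@H]2c3cc(C#N)ccc3OC(C)(C)[C@H]2O)NC#N)c1`) gives 1400 nM and so stands within the scatter of compound 1 (`CC1(C)Oc2ccc(C#N)cc2[C@@H](/N=C(\NC#N)Nc2ccc(Cl)cc2)[C@@H]1O`), which gives 1800 nM in the same test. Compound 2 (`CC1(C)Oc2ccc(C#N)cc2[C@@H](/N=C(\NC#N)Nc2ccccc2)[C@@H]1O`) gives 1400 nM; 1300 nM (2 entries) on repeated testing. Compound 4 (`CC1(C)Oc2ccc(C#N)cc2[C@@H](/N=C(\NC#N)Nc2ccc(Cl)c(Cl)c2)[C@@H]1O`) differs from compound 3 in one group (3,4-dichlorophenyl in place of 3-(methylsulfanyl)phenyl on an amine nitrogen), with 3,4-dichlorophenyl in place of 3-(methylsulfanyl)phenyl on an amine nitrogen. Among the compounds with values here, the one measured step at that place (a 1.3-fold lower number from compound 1 to compound 3 (0.11 log units; within the scatter)) stayed within the scatter, so in this assay no shift beyond the scatter is expected in either direction. The expected step is small (no change at the digits printed from compound 3 to compound 4 (within the scatter)) on this estimate. Compound 4 is therefore expected at 1400 nM within an estimated range of 600 nM to 3200 nM in this test.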

Compound 4, half-maximal inhibitory concentration: 4600 nM
Compound 4: the middle estimate sits 3.3-fold (0.52 log units) below what was measured, outside the stated range (above it).
By their numbers in this assay, from the lowest: compounds 3 and 1 (each within the scatter of the next); then compound 4.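

In this assay, the group on this amine nitrogen proves less freely exchangeable than the earlier step suggested: 3,4-dichlorophenyl in place of 3-(methylsulfanyl)phenyl gives a 3.3-fold higher number from compound 3 to compound 4 (0.52 log units; beyond the scatter). Adding a single chloro to the 4-chlorophenyl group also gives a 2.6-fold higher number from compound 1 to compound 4 (0.41 log units; beyond the scatter), so this one added atom is enough to weaken inhibition beyond the scatter. Repeated readings of one compound in this test lie close together: the several entries of compound 2 in this assay, 1400 nM; 1300 nM (2 entries)

From the compounds shown here alone, it remains open whether a fluoro or methoxy group on the phenyl ring would weaken inhibition in the same way. A pyridine ring in place of the phenyl ring is also untested among the compounds shown here.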